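Reversing Two Stereo Elements of Compound 2

The source may report more compounds than this note shows. Statements on the series, on what has been measured and on what is new or still open speak of the compounds shown alone.

Measured in a functional assay on HL-60 cells (Homo sapiens) for cytotoxicity; a lower number here means a stronger inhibitor, a higher number a weaker inhibitor:
- compound 1 `COC(=O)[C@]12CC(=O)[C@H](C(C)C)CC(=O)/C(C)=C/CC/C(C)=C\C(=O)[C@H]1CC(C)=C1C[C@H](O)[C@](C)(O)[C@H]3CC[C@@](C)(O)[C@H](CC/C(C)=C/[C@@H]12)O3` gives 41000 nM
- compound 2 `COC(=O)[C@]12CC(=O)[C@H](C(C)C)CC(=O)/C(C)=C/CC/C(C)=C/C(=O)[C@H]1CC(C)=C1C[C@H](O)[C@](C)(O)[C@H]3CC[C@](C)(O3)[C@@H](O)CC/C(C)=C/[C@@H]12` gives 58000 nM

These two values lie within the scatter of each other, so compound 2 stands level with compound 1 and neither can be ranked above the other. Both sit in the same weak range of the read-out.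

Compound 3 (`COC(=O)[C@]12CC(=O)[C@H](C(C)C)CC(=O)/C(C)=C/CC/C(C)=C\C(=O)[C@H]1CC(C)=C1C[C@H](O)[C@](C)(O)[C@H]3CC[C@@](C)(O3)[C@@H](O)CC/C(C)=C/[C@@H]12`) has not yet been measured. It is related to compound 2 by configuration alone (the two compounds have the same atoms and bonds and differ only in configuration as drawn: 2 of 12 stereo elements differ; a stereocentre at a saturated ring carbon is drawn S in compound 2 and R in compound 3; a double bond is drawn E in compound 2 and Z in compound 3) and no atom or bond leaves or enters. A stereocentre at a saturated ring carbon is drawn S in compound 2 and R in compound 3, and a double bond is drawn E in compound 2 and Z in compound 3.

Going by the values given here, no measured pair here shows the size of such a change. Among the compounds with values here, the only anchors are compound 1 at 41000 nM and compound 2 at 58000 nM and they point to no particular direction. In this assay no step beyond the scatter is expected, and the estimated step stays small (a 1.2-fold lower number from compound 2 to compound 3 (0.06 log units; within the scatter)). For compound 3 the estimated value is 50000 nM (expected range 20000 nM to 120000 nM).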

Compound 3, half-maximal inhibitory concentration: 47800 nM
Compound 3: middle estimate off by 1.0-fold (0.02 log units), on the high side; the range from low to high includes it.
By their numbers in this assay, from the lowest: compounds 1, 3 and 2 (each within the scatter of the next).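

In this assay, reversing the stereocentre at a saturated ring carbon from S to R together with the double bond from E to Z gives a 1.2-fold lower number from compound 2 to compound 3 (0.08 log units; within the scatter). Going by these compounds alone, this is the first measured step, as no step could be read between compound 1 and compound 2, and it shows that this combined reversal, at these two stereo elements, leaves the read-out within the scatter. The comparison concerns configuration alone, with no atom or bond leaving or entering, so the pair reads on stereochemistry without any change of group being mixed in: the fact that compounds 2 and 3 differ only in the configuration as drawn.

The compounds shown leave open what each of the two stereo elements does on its own, since both differ together in this pair, and whether two separate effects cancel one another or neither has any effect on the read-out. They also leave open whether the same lack of a measurable step would hold on a shared core carrying a carboxylic acid or an amine.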